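A few compounds are considered here, and "the series" means these few. Any claim that something is new, unique, unknown or untested is made for them only; others in the source may bear on it.

Compound 1 `COc1cc2[nH]c(C)c(-c3ccncc3)c(=O)c2cc1Cl` carries a pyridin-4-yl group on the shared core. In an ADME assay on J774 cells (Mus musculus) for cytotoxicity, with a stated time of 72 h (on this read-out lower numbers stand for an effect already at smaller amounts and higher numbers for an effect only at larger amounts of compound), compound 1 gives > 33300 nM, which is a limit of the assay and not a number. Compound 2 `COc1cc2[nH]c(C)c(-c3ccc(N(C)C)nc3)c(=O)c2cc1Cl` gives > 29100 nM, which is also a limit. Compound 3 `COc1cc2[nH]c(C)c(-c3ccoc3)c(=O)c2cc1Cl` gives > 34500 nM, again a limit. All three values are therefore limits, and compound 1 has no exact place among them.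

Compound 4 `COc1cc2[nH]c(C)c(-c3c(C)noc3C)c(=O)c2cc1Cl` has not yet been measured. Its change from compound 1 is 3,5-dimethyl-1,2-oxazol-4-yl in place of pyridin-4-yl on an aromatic carbon, ortho to a methyl group.

Within the data shown here, only one measured step bears on this swap, the exchange of pyridin-4-yl for furan-3-yl. It is a step that the two limits leave unreadable from compound 1 to compound 3, so it offers no size to carry over. It does show that compound 3, with another aromatic group at that place, stayed at a limit of > 34500 nM.

In this assay, the expected result is therefore no step beyond the scatter in either direction, with the estimated change being an at least 1.0-fold lower number from compound 1 to compound 4 (0.03 log units; that floor lies within the scatter). Another limit is the most likely report. The estimate for compound 4 is 31000 nM, with an expected range of 15000 nM to 40000 nM.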

Compound 4, half-maximal effective concentration: > 31400 nM
Compound 4: no number, only a limit; the forecaster's own chance of this, stated with the estimate: 85%; middle value at least 1.0-fold (0.00 log units) away from the limit.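

In this assay, compound 4 is reported only as a limit, as are compound 1 and compound 3, so the steps from compound 1 and from compound 3 to compound 4 cannot be read. The compounds shown leave open at what concentration any of them would reach a half-maximal effect on these cells, and whether the exchanged aromatic groups change that concentration.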